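Aminotriazine series: fluoro to methoxy on the benzylamine ring

A few compounds are considered here, and "the series" means these few. Any claim that something is new, unique, unknown or untested is made for them only; others in the source may bear on it.

Compound 1 `Cc1ccccc1-c1nc(N)nc(NCc2ccccc2)n1` carries a methyl-substituted phenyl on the shared core, and in a functional assay on cells for positive allosteric modulation of G-protein coupled receptor 68 (Homo sapiens), read by a luciferase reporter and cAMP accumulation, with a stated time of 30 min, at pH 6.8 and pH 8.3, in the presence of a further agent that is not named here (a lower number here means a less potent compound, a higher number a more potent compound, by a factor of ten per unit of this negative logarithm), compound 1 gives "not active" (no number reported), with no number given. Going by the values given here, compound 2 `Nc1nc(NCc2cccc(F)c2)nc(-c2ccccc2CO)n1` bears a hydroxymethyl on its phenyl and a fluoro on the benzylamine ring; in this assay compound 2 gives 4.52, the only number in the set, so it stands alone rather than in a ranking. Compound 3 `COc1cccc(CNc2nc(N)nc(-c3ccccc3CO)n2)c1` differs from compound 2 by methoxy in place of fluoro on an aromatic carbon, a swap on an aromatic carbon of a six-membered aromatic ring of carbon only. Among the compounds with values here, no step between two measured compounds exists to calibrate this change. The step from compound 2 to compound 3 is expected to be small, not beyond the usual scatter, in either direction: a number 0.08 log units higher from compound 2 to compound 3 (within the scatter). Compound 3 is expected to give an estimated 4.6 in this assay, within the range 4 to 5.2.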

Compound 3, negative logarithm of the antagonist equilibrium constant: 4.11
Estimate against measurement, compound 3: 0.49 log units above, and the stated range covers the measured number.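

In this assay, going by these compounds alone, the change from 3-fluorophenyl to 3-methoxyphenyl gives a number 0.41 log units lower from compound 2 to compound 3 (beyond the scatter), the first step that can be read at this place on the ring. The number is modest in size, but it shows that this aromatic carbon, meta to a large group, does not tolerate the swap without a change: with the hydroxymethyl phenyl held constant, methoxy reads lower than fluoro. No measurement given here bears on the reason for this step.

A single step leaves open how a chloro group, an amine or a longer chain such as ethoxy would read at this carbon. From the compounds shown here alone, it also remains open whether the same swap would give a similar step with another group on the phenyl attached to the shared core.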